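This account rests on a few compounds, and the source may have more. Where it says the series, first, only, none or still open, it means among the compounds named here.

Working notes on the series. Compound 1 `COC1=C(C)C(=O)/C(=C(O)/C=C/c2ccccc2C)C(=O)C1(C)C` and compound 2 `COC1=C(C)C(=O)/C(=C(O)/C=C/c2c(C)cccc2C)C(=O)C1(C)C` share one core; compound 3 `CCC1=C(OC)C(CC)(CC)C(=O)C(C(=O)/C=C/c2ccccc2)=C1O` and compound 4 `CCC1=C(OC)C(CC)(CC)C(=O)C(C(=O)/C=C/c2ccc(C)cc2)=C1O` share another, and the difference between the two cores is not broken down here.

In a functional assay on HUVEC cells (Homo sapiens) (on this read-out lower numbers stand for an effect already at smaller amounts and higher numbers for an effect only at larger amounts of compound), compound 1 gives < 4 ug/mL, which is a limit of the assay and not a number. Compound 2 in this assay gives < 4 ug/mL, again a limit. Compound 3 in this assay gives < 4 ug/mL, once more a limit.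

The change from compound 1 to compound 2 is methyl in place of hydrogen on an aromatic carbon. Its step, a step that the two limits leave unreadable from compound 1 to compound 2, cannot be read, which the limit of < 4 ug/mL in this assay, at which 3 of the 3 values shown sit, records: all three values sit at the same limit. The change from compound 3 to compound 4 is methyl in place of hydrogen on an aromatic carbon, the same kind of change but not the same, as the place differs: in compound 2 the new methyl stands ortho to a large group and meta to a methyl group, while in compound 4 it stands para to a large group.

For compound 4 the step that the limit leaves unreadable from compound 3 to compound 4 is expected to be small, resting on compound 3 at < 4 ug/mL and on the unreadable step that the two limits leave unreadable from compound 1 to compound 2. Compound 4 is therefore estimated at 2 ug/mL, with an expected range from 0.5 ug/mL to 5 ug/mL, and most likely reported again only as a limit.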

Compound 4, concentration for half-maximal effect: < 4 ug/mL
Compound 4: only a limit was reported (the forecaster's own chance of this, stated with the estimate: 80%); the middle value lies beyond the limit too.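

In this assay compound 4 gives < 4 ug/mL, a limit of the assay and not a number. With compound 3 at the same limit, no new step can be read between compound 3 and compound 4: the limit of < 4 ug/mL in this assay, at which 4 of the 4 values shown sit.

As far as these compounds go, what stays open is whether the added methyl shifts the read-out in this assay at all, and how compound 1, compound 2, compound 3 and compound 4 rank against one another.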